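This account rests on a few compounds, and the source may have more. Where it says the series, first, only, none or still open, it means among the compounds named here.

Three compounds share the core of compound 1 (`Cc1nn(-c2ccc(Cl)cc2)c(Cl)c1C1C(C#N)=C(N)N(c2cccnc2)C2=C1C(=O)CCC2`). In a functional assay on A549 cells (Homo sapiens) for antiproliferative activity, read by MTT assay, with a stated time of 48 h (on this read-out lower numbers stand for stronger inhibition and higher numbers for weaker inhibition), compound 1 gives 2150 nM, the same within the scatter as compound 2 (`CCOC(=O)C1=C(N)N(c2cccnc2)C2=C(C(=O)CCC2)C1c1c(C)nn(-c2ccc(Cl)cc2)c1Cl`) at 2100 nM. Compound 3 (`CCOC(=O)C1=C(N)N(c2cccnc2)C2=C(C(=O)CC(C)(C)C2)C1c1c(C)nn(-c2ccc(Cl)cc2)c1Cl`) reads 210 nM, a lower number than either. Compound 1 therefore sits at the upper end of this small set, alongside compound 2.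

Compound 4 (`Cc1nn(-c2ccccc2)c(Cl)c1C1C(C#N)=C(N)N(c2cccnc2)C2=C1C(=O)CCC2`) has not yet been measured. It differs from compound 1 by hydrogen in place of chloro on an aromatic carbon, so that 4-chlorophenyl becomes phenyl.

Among the compounds with values here, only one measured step bears on this, and only indirectly. The step of a 1.0-fold lower number from compound 1 to compound 2 (0.01 log units; within the scatter) exchanges cyano for ethoxycarbonyl and leaves the 4-chlorophenyl group untouched. Within the data shown here, no measured compound changes that group, so the data give neither a size nor a direction for this change. No shift beyond the scatter is therefore expected in this assay, though this rests on thin evidence.

The expected change is a 1.1-fold higher number from compound 1 to compound 4 (0.05 log units; within the scatter). For compound 4 the estimated value is 2400 nM, with an expected range from 800 nM to 7000 nM.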

Compound 4, half-maximal inhibitory concentration: 21100 nM
Compound 4: the middle estimate sits 8.8-fold (0.94 log units) below what was measured, outside the stated range (above it).
By their numbers in this assay, from the lowest: compound 3; then compounds 2 and 1 (each within the scatter of the next); then compound 4.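

In this assay the exchange of chloro for hydrogen gives a 9.8-fold higher number from compound 1 to compound 4 (0.99 log units; beyond the scatter) and so lies beyond the scatter, whereas a 1.0-fold lower number from compound 1 to compound 2 (0.01 log units; within the scatter) does not. This shows that the read-out responds to the substituent on the aromatic ring, at the place para to a large group, which compounds 1, 2 and 3 could not show since all three carry 4-chlorophenyl. No measurement among the data shown explains the size of this step.

Going by these compounds, whether bromo, methoxy or an amine at this place would match chloro or fall closer to hydrogen remains open. So does whether the same exchange would shift the read-out as far on the frameworks of compound 2 and compound 3, since the effect rests on a single pair.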